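Swapping the ring on the carbon double-bonded to nitrogen

The source may report more compounds than this note shows. Statements on the series, on what has been measured and on what is new or still open speak of the compounds shown alone.

Three compounds sharing one core and differing only in the ring on the carbon with a double bond to nitrogen have been measured in a functional assay on HT-29 cells (Homo sapiens) for cytotoxicity, read by MTT assay, with a stated time of 72 h; on this read-out lower numbers stand for stronger inhibition and higher numbers for weaker inhibition. Compound 1 `COc1cc2c(Oc3ccc(NC(=O)N/N=C/c4ccc(F)cc4Cl)cc3F)ccnc2cc1OCCCN1CCCCC1` gives 260 nM in this assay, compound 2 `COc1cc2c(Oc3ccc(NC(=O)N/N=C/c4ccc(OC(F)(F)F)cc4)cc3F)ccnc2cc1OCCCN1CCCCC1` gives 510 nM, and compound 3 `C=CCc1cccc(/C=N/NC(=O)Nc2ccc(Oc3ccnc4cc(OCCCN5CCCCC5)c(OC)cc34)c(F)c2)c1OC` gives 460 nM. Among these three numbers compound 3 stands second highest: its nearest neighbour is compound 2, with a 1.1-fold lower number from compound 2 to compound 3 (0.04 log units; within the scatter), and its furthest is compound 1, with a 1.8-fold higher number from compound 1 to compound 3 (0.25 log units; within the scatter). The remaining measured step, a 2.0-fold higher number from compound 1 to compound 2 (0.29 log units; within the scatter), is likewise small. Compound 4 `COc1cc2c(Oc3ccc(NC(=O)N/N=C/c4ccncc4)cc3F)ccnc2cc1OCCCN1CCCCC1` differs from compound 3 in a single place: pyridin-4-yl in place of 3-allyl-2-methoxyphenyl on a carbon with a double bond to nitrogen. All three measured steps bear on this position because a 2.0-fold higher number from compound 1 to compound 2 (0.29 log units; within the scatter), a 1.8-fold higher number from compound 1 to compound 3 (0.25 log units; within the scatter) and a 1.1-fold lower number from compound 2 to compound 3 (0.04 log units; within the scatter) each exchange the ring on the same carbon, and none of them leaves the scatter. Among the compounds with values here, the pyridin-4-yl ring, however, is the first with a hetero atom in the ring and the smallest tried here, so no measured step covers it directly. The expectation is therefore a step no larger than the scatter, with a widened range. Compound 4 is expected to give about 550 nM in this assay, between 180 nM and 1700 nM. The step this estimate means is expected to be a 1.2-fold higher number from compound 3 to compound 4 (0.08 log units; within the scatter).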

Compound 4, half-maximal inhibitory concentration: 940 nM
The estimate for compound 4 lay 1.7-fold (0.23 log units) below the measured number; the measured number falls inside the stated range.
By their numbers in this assay, from the lowest: compounds 1, 3, 2 and 4 (each within the scatter of the next, the first and the last beyond it).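

Within the data shown here, at this position, on a carbon with a double bond to nitrogen, pyridin-4-yl gives the first ring exchanges beyond the scatter in this assay with a 2.0-fold higher number from compound 3 to compound 4 (0.31 log units; beyond the scatter) and a 3.6-fold higher number from compound 1 to compound 4 (0.56 log units; beyond the scatter), both modest, so the position is not wholly indifferent to the ring it carries. Against any claim that pyridin-4-yl stands apart from all the carbon-only rings, a 1.8-fold higher number from compound 2 to compound 4 (0.27 log units; within the scatter) stays within the scatter, which separates compound 4 from compound 1 and compound 3 but not from compound 2. The change from 3-allyl-2-methoxyphenyl to pyridin-4-yl alters the ring's make-up and its size together, from 11 heavy atoms to 6, and nothing available here separates those two changes or accounts for the steps.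

The compounds shown leave open whether the ring nitrogen or the absence of further groups on the ring goes with the step, a question that an unsubstituted phenyl ring could address. They also leave open whether the place of that nitrogen matters, as pyridin-3-yl or pyridin-2-yl on the same carbon could show.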